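This account rests on a few compounds, and the source may have more. Where it says the series, first, only, none or still open, it means among the compounds named here.

Compound 1, with the structure `NC(=O)CCCCc1c[nH]c2ccc(F)cc12`, is the starting point here. In an assay on isolated protein for inhibition of Myeloperoxidase (Homo sapiens), read by ELISA, with a stated time of 5 min (a higher number here means a weaker inhibitor, a lower number a stronger inhibitor), compound 1 gives 43 nM. Two other compounds share its core. Compound 3, with the structure `NC(=O)CCc1c[nH]c2c(F)cccc12`, gives 64 nM in this assay; the gap between compound 1 and compound 3 is within the scatter of repeated measurements, so the two cannot be placed in any order. Compound 2, with the structure `NCCCc1c[nH]c2ccc(C(=O)O)cc12`, is reported in this assay as "not active" (no number reported), with no number attached, and it carries a carboxylic acid and a 3-aminopropyl chain that the other two do not.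

The next compound, compound 4, has the structure `NCCSCCc1c[nH]c2ccc(F)cc12`. It differs from compound 1 in one place: (2-aminoethyl)sulfanyl in place of 2-carbamoylethyl on a saturated chain carbon, two bonds along the chain from an aromatic carbon. Among the compounds with values here, no pair of measured compounds shows a step of this kind, so the size of the step can only be expected, not read off.

The only compound shown with a free primary amine on its chain is compound 2, for which no number is given. On that footing, compound 4 is expected to inhibit somewhat less strongly than compound 1, a step of a 3.5-fold higher number from compound 1 to compound 4 (0.54 log units; beyond the scatter) toward weaker inhibition, with the usual scatter making no change also possible. The estimate for compound 4 in this assay is 150 nM, within a range from 40 nM to 600 nM.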

Compound 4, half-maximal inhibitory concentration: 8 nM
Compound 4: middle estimate off by 19-fold (1.27 log units), on the high side, outside the stated range (below it).
By their numbers in this assay, from the lowest: compound 4; then compounds 1 and 3 (each within the scatter of the next).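

In this assay the change from 2-carbamoylethyl to (2-aminoethyl)sulfanyl, on a saturated chain carbon two bonds along the chain from an aromatic carbon, gives a 5.4-fold lower number from compound 1 to compound 4 (0.73 log units; beyond the scatter) toward stronger inhibition. Within the data shown here, this is the first step at this place whose size can be read from two measured numbers, and it shows that the amide end of the chain is not needed for compound 4 to inhibit the enzyme strongly: a chain that ends in an amine and holds a sulfur atom does better here than the chain of compound 1. Nothing available here explains why the number falls.

The change swaps the end of the chain and brings in the sulfur in a single move, so the compounds shown cannot tell which of the two accounts for the step. A chain of the same kind with a carbon in place of the sulfur, or a sulfur-containing chain ending in an amide or a carboxylic acid, would separate the two parts, and a longer or shorter amine chain on the same core remains untested among these compounds.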